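Arylpiperazine Swap on the Shared Core: Working Notes

The source may report more compounds than this note shows. Statements on the series, on what has been measured and on what is new or still open speak of the compounds shown alone.

The series shares a core carrying an arylpiperazine on an alkyl chain; compound 1 is `CCC1(CCCCN2CCN(c3ccc(C)c(Cl)c3)CC2)C(=O)Nc2ccccc21`, compound 2 is `CCC1(CCCN2CCN(c3cccc(Cl)c3)CC2)C(=O)Nc2ccccc21`, compound 3 is `CCC1(CCCCN2CCN(c3cccc(Cl)c3)CC2)C(=O)Nc2cc(F)c(Cl)cc21` and the untested compound 4 is `CCC1(CCCCN2CCN(c3ccccc3OC)CC2)C(=O)Nc2ccccc21`. In a functional assay on the whole organism (strain Wistar) with Rattus norvegicus as the target, with a stated time of 5 min (on this read-out lower numbers stand for an effect already at smaller amounts and higher numbers for an effect only at larger amounts of compound), compound 1 gives only a limit, > 20 mg/kg. Compound 2 likewise reaches only a limit, > 20 mg/kg, in this assay. For the measured compounds named here, compound 3 is the one member with a number in this assay, 20 mg/kg. Going by the values given here, compound 1 therefore stands where most of the series sits, at the limit of > 20 mg/kg in this assay, at which 2 of the 3 values shown sit, and no measured pair differs in a single place, so no step size can be read off within this set.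

The change to compound 4 is 2-methoxyphenyl in place of 3-chloro-4-methylphenyl on an amine nitrogen in a ring. Among the compounds with values here, with two limits and one value at the same dose, this assay gives no direction for the step; any movement from compound 1 to compound 4 is expected to stay within the scatter, and a further limit is as likely as a number. Compound 4 is thus estimated at 20 mg/kg, within 7 mg/kg to 40 mg/kg, meaning an expected step of a number no higher from compound 1 to compound 4 (the limit leaves the size open) from compound 1 to compound 4.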

Compound 4, minimum effective dose: 10 mg/kg
Compound 4: the middle estimate sits 2.0-fold (0.30 log units) above what was measured, within the range that was stated.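

In this assay, for the compounds shown here, the swap on an amine nitrogen in a ring gives the first step that can be read at this place: an at least 2.0-fold lower number from compound 1 to compound 4 (0.30 log units; that floor lies within the scatter). From the compounds shown here alone, the groups leaving and entering match in heavy-atom count and in their single aromatic ring, while chlorine gives way to oxygen and one hydrogen-bond acceptor enters, so this exchange alone is enough to turn a limit into a number on the otherwise unchanged structure of compound 1, although the true size of the step stays unknown and its floor does not clear the usual scatter. A limit is thus not the only outcome for this core, though limits remain common across the set: the limit of > 20 mg/kg in this assay, at which 2 of the 4 values shown sit.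

The compounds shown do not separate the arrival of the methoxy group from the loss of the chlorine and the methyl, so an unsubstituted phenyl or a 2-hydroxyphenyl on the same nitrogen would be the telling comparison. Going by these compounds, it also remains open whether 2-methoxyphenyl would give a similar read-out with a shorter chain or with the fluoro and chloro groups on the shared core.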